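The compounds below may be only part of what the source reports. "The series", "measured", "known", "first", "only" and "open" are said of these compounds alone.

Measured so far:
compound 1 `CC(C)n1nc(-c2cc(C3CCCCC3)on2)c2c(N)ncnc21` — 910 nM
compound 2 `CC(C)n1nc(-c2cc(-c3ccc(F)cc3)on2)c2c(N)ncnc21` — 150 nM

For the measured compounds named here, in an assay on isolated protein for inhibition of proto-oncogene tyrosine-protein kinase receptor Ret (Homo sapiens), read by radiometric assay and 33P incorporation, in the presence of a further agent that is not named here (on this read-out lower numbers stand for stronger inhibition and higher numbers for weaker inhibition), compound 2 gives 150 nM, the lowest of the two numbers; the only neighbour is compound 1 at 910 nM, and the step of a 6.1-fold lower number from compound 1 to compound 2 (0.78 log units; beyond the scatter) is a 4-fluorophenyl in place of cyclohexyl on an aromatic carbon.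

Compound 3 `CCc1cc(-c2nn(C(C)C)c3ncnc(N)c23)no1` carries ethyl in place of 4-fluorophenyl on an aromatic carbon. Going by the values given here, only the step from compound 1 to compound 2 bears on this, showing an aromatic ring at that carbon beating a saturated one. Ethyl removes the ring and most of the bulk; a rise in the number beyond the scatter is expected, a 10-fold higher number from compound 2 to compound 3 (1.00 log units; beyond the scatter). Compound 3 is therefore estimated at 1500 nM (range 400 nM to 6000 nM).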

Compound 3, half-maximal inhibitory concentration: 41 nM
Estimate against measurement, compound 3: 37-fold (1.56 log units) above; measured number below the stated range.
By their numbers in this assay, from the lowest: compound 3; then compound 2; then compound 1.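

In this assay, an aromatic ring is not required at this carbon: ethyl in place of 4-fluorophenyl gives a 3.7-fold lower number from compound 2 to compound 3 (0.56 log units; beyond the scatter), reversing the preference that the cyclohexyl comparison alone suggested. Ethyl in place of cyclohexyl gives a 22-fold lower number from compound 1 to compound 3 (1.35 log units; beyond the scatter), so the smallest of the three groups has the lowest number, although the 4-fluorophenyl of compound 2 still falls below the cyclohexyl of compound 1 and goes against any simple trend with size. Nothing available explains this order.

Open, going by these compounds, is whether methyl, propyl or a longer chain would lower the number further. Also open, on these data alone, is how an amine or a hydroxymethyl at this carbon would compare with ethyl.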